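Removing the Bromo Substituent from Compound 1

A few compounds are considered here, and "the series" means these few. Any claim that something is new, unique, unknown or untested is made for them only; others in the source may bear on it.

Among the measured compounds shown here, compound 1 `CC(N)CSc1ccccc1Br` stands lowest of the three numbers so far in an assay on isolated protein for inhibition of Amine oxidase [flavin-containing] A (Homo sapiens), read by fluorescence and spectrophotometry; a lower number here means a stronger inhibitor, a higher number a weaker inhibitor: compound 1 gives 724 nM there. Its nearest neighbour is compound 3 `Cc1cccc(C)c1[Se]CC(C)N`, which in this assay gives 1680 nM, a step beyond the scatter. Furthest away is compound 2 `CC(N)CSc1ccc(Br)cc1`, which gives 3890 nM, also well beyond the scatter. No two of these three differ in one place only, so their numbers are simply set side by side.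

Compound 4 `CC(N)CSc1ccccc1` has not yet been measured in this assay. It differs from compound 1 by hydrogen in place of bromo on an aromatic carbon. For the measured compounds named here, no measured pair shows the removal of a bromo group alone, so the size of the step rests only on the spread among compounds 1, 2 and 3. Compound 4 is expected to weaken, with a step of a 2.5-fold higher number from compound 1 to compound 4 (0.40 log units; beyond the scatter) somewhat beyond the scatter. Compound 4 is therefore estimated at 1800 nM, within a range from 600 nM to 6000 nM.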

Compound 4, half-maximal inhibitory concentration: 4720 nM
For compound 4 the middle estimate is 2.6-fold (0.42 log units) below the measured one; low and high end bracket the measured number.
By their numbers in this assay, from the lowest: compound 1; then compound 3; then compounds 2 and 4 (each within the scatter of the next).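

In this assay, hydrogen in place of the bromo ortho to a group of 5 heavy atoms gives a 6.5-fold higher number from compound 1 to compound 4 (0.81 log units; beyond the scatter), the first direct sign that the bromo at this place counts towards the inhibition seen with compound 1. The same replacement on compound 2, whose bromo sits elsewhere on the aromatic ring, gives only a 1.2-fold higher number from compound 2 to compound 4 (0.08 log units; within the scatter), so among these compounds the effect of removing a bromo depends on where it stood, and only the bromo of compound 1 separates from hydrogen. The data offer no measurement that would explain this difference.

On these data alone, whether a chloro or a methoxy group at the same aromatic carbon would match the bromo remains open. Also open, as far as these compounds go, is whether the step would hold on a core carrying a longer chain.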